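Swapping a phenyl for a methoxy on the fused ring

The source may report more compounds than this note shows. Statements on the series, on what has been measured and on what is new or still open speak of the compounds shown alone.

Three compounds from this series share one core and differ only in the group on the fused ring. Compound 1 `Cc1c(C(=O)Nc2ccc(Oc3ncnc4[nH]cc(-c5ccccc5)c34)c(F)c2)c(=O)c2cc(C(C)C)ccc2n1C` carries an isopropyl there; in an assay on isolated protein for inhibition of tyrosine-protein kinase receptor UFO (Homo sapiens), read by FRET and Z'-LYTE, with a stated time of 1.5 h (on this read-out lower numbers stand for stronger inhibition and higher numbers for weaker inhibition), compound 1 gives 26 nM. Compound 2 `CCCc1ccc2c(c1)c(=O)c(C(=O)Nc1ccc(Oc3ncnc4[nH]cc(-c5ccccc5)c34)c(F)c1)c(C)n2C` carries a propyl instead, and in this assay compound 2 gives 61 nM, a change described by a 2.3-fold higher number from compound 1 to compound 2 (0.37 log units; beyond the scatter). Compound 3 `Cc1c(C(=O)Nc2ccc(Oc3ncnc4[nH]cc(-c5ccccc5)c34)c(F)c2)c(=O)c2cc(-c3ccccc3)ccc2n1C` carries a phenyl at the same place. In this assay, within the data shown here, compound 3 gives only a limit, > 10000 nM, so its exact number is unknown; it is the one value resting at the limit of > 10000 nM in this assay, at which 1 of the 3 values shown sits. The steps to it are large: an at least 380-fold higher number from compound 1 to compound 3 (2.58 log units; beyond the scatter) and an at least 160-fold higher number from compound 2 to compound 3 (2.21 log units; beyond the scatter).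

Compound 4 `COc1ccc2c(c1)c(=O)c(C(=O)Nc1ccc(Oc3ncnc4[nH]cc(-c5ccccc5)c34)c(F)c1)c(C)n2C` is the next member, and its change from compound 3 is methoxy in place of phenyl on an aromatic carbon. Both measured steps that end at compound 3 show the phenyl as the cause of the loss; a smaller group, whether isopropyl or propyl, sits far lower on the scale. A methoxy is likewise small, so compound 4 is expected to move back toward that range, a step estimated as an at least 66-fold lower number from compound 3 to compound 4 (1.82 log units; beyond the scatter). For compound 4 the expected value in this assay is therefore 150 nM, with a likely range from 30 nM to 1500 nM.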

Compound 4, half-maximal inhibitory concentration: 99 nM
For compound 4 the middle estimate is 1.5-fold (0.18 log units) above the measured one; low and high end bracket the measured number.
By their numbers in this assay, from the lowest: compound 1; then compounds 2 and 4 (each within the scatter of the next). At a limit, above all of these: compound 3.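

Compound 4 shows that this place on the ring can hold a group carrying oxygen, with one hydrogen-bond acceptor where the phenyl has none, and the change produces an at least 100-fold lower number from compound 3 to compound 4 (2.00 log units; beyond the scatter). Against the propyl, the methoxy gives a 1.6-fold higher number from compound 2 to compound 4 (0.21 log units; within the scatter), so these two groups cannot be told apart here, while against the isopropyl it gives a 3.8-fold higher number from compound 1 to compound 4 (0.58 log units; beyond the scatter), a modest step that leaves compound 1 with the lowest number of the set. Compound 3 stands at a limit, so the true size of its step to compound 4 stays unknown: the limit of > 10000 nM in this assay, at which 1 of the 4 values shown sits.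

Going by these compounds, what remains open is whether the loss at compound 3 belongs to aromatic rings in general or to the phenyl alone, a question that a cyclohexyl or a pyridine ring at the same place would help to answer. Nor do these compounds show whether the oxygen of the methoxy matters at all, or how far the place tolerates an ethyl, an amine, a carboxylic acid or a longer chain such as butyl.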